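This account rests on a few compounds, and the source may have more. Where it says the series, first, only, none or still open, it means among the compounds named here.

In a functional assay on SK-OV-3 cells (Homo sapiens) for antiproliferative activity, read by MTT assay, with a stated time of 24 h (a higher number here means a weaker inhibitor, a lower number a stronger inhibitor), three chalcones on a shared core have been measured. Compound 1 `COc1cccc(/C=C/C(=O)c2ccc(OC)c3c2OC(C)(C)C=C3)c1` gives 9360 nM. For compound 2 `COc1ccc(C(=O)/C=C/c2ccc(Br)cc2)c2c1C=CC(C)(C)O2` the assay reports only a limit, > 10000 nM. For compound 3 `COc1ccc(C(=O)/C=C/c2ccc(C(F)(F)F)cc2)c2c1C=CC(C)(C)O2` the reading is likewise a limit, > 10000 nM. Compound 3 therefore stands at the ceiling of this assay, with no number of its own, and the same holds for (the limit of > 10000 nM in this assay, at which 2 of the 3 values shown sit). Going by the values given here, the one readable step, an at least 1.0-fold higher number from compound 1 to compound 2 (0.02 log units; that floor lies within the scatter), sits at the floor of a limit and says little, while a step that the two limits leave unreadable from compound 2 to compound 3 cannot be sized from two limits.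

Compound 4 `COc1ccc(C(=O)/C=C/c2ccccc2)c2c1C=CC(C)(C)O2` differs from compound 3 only in one place: hydrogen in place of trifluoromethyl on an aromatic carbon. Among the compounds with values here, no measured step among compounds 1, 2 and 3 shows that a change at this carbon moves the half-maximal inhibitory concentration beyond the scatter, and the only numeric value, that of compound 1 in this assay, 9360 nM, is itself a high number. The expected step that the limit leaves unreadable from compound 3 to compound 4 is therefore no change beyond the scatter, with a real chance that compound 4 also returns only a limit. Compound 4 is estimated at about 11000 nM, in a range from 5000 nM to 30000 nM.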

Compound 4, half-maximal inhibitory concentration: > 10000 nM
Compound 4 gave a limit, no number; the forecaster's own chance of this, stated with the estimate: 55%; the middle value does not contradict the limit.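

With hydrogen on this aromatic carbon, para to a large group, this assay still returns no number, so taking away the trifluoromethyl group does not bring the reading under the limit. Going by these compounds alone, the steps among compound 2, compound 3 and compound 4 cannot be read, since all three values are limits, and the only step that can be read is an at least 1.0-fold higher number from compound 1 to compound 4 (0.02 log units; that floor lies within the scatter), which does not separate the two compounds. This carbon has now carried bromo, trifluoromethyl and hydrogen with the same limit each time, and the series as shown reads: the limit of > 10000 nM in this assay, at which 3 of the 4 values shown sit.

On these data alone, how far compound 2, compound 3 and compound 4 lie beyond that limit, and whether they differ from one another at all, remains open, so no order among bromo, trifluoromethyl and hydrogen can be given. Also open, as far as these compounds go, is whether an amine or a carboxylic acid on this aromatic carbon would give a real number in this assay, and whether such a number would differ from the value of compound 1 by more than the scatter.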